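A few compounds are considered here, and "the series" means these few. Any claim that something is new, unique, unknown or untested is made for them only; others in the source may bear on it.

Measured in a functional assay on HCT-116 cells (Homo sapiens) for inhibition, read by luminescence and resazurin assay, with a stated time of 3 days; a lower number here means a stronger inhibitor, a higher number a weaker inhibitor:

- compound 1 `Cc1ccc(S(=O)(=O)Nc2ccc(CNc3nc(N(C)C)nc4ccccc34)cc2)cc1` gives 11000 nM
- compound 2 `CN1CCN(c2nc(NCc3ccc(NC(=O)c4ccncc4)cc3)c3ccccc3n2)CC1` gives > 20000 nM, which is a limit

Compound 2 yields no number, only a limit, and stands at the limit of > 20000 nM in this assay, at which 1 of the 2 values shown sits.

The step from here leads to compound 3 `Cc1ccc(S(=O)(=O)Nc2ccc(CNc3nc(N4CCN(C)CC4)nc4ccccc34)cc2)cc1`, which is still to be tested. The change is (4-methylphenyl)sulfonyl in place of (pyridin-4-yl)carbonyl on a nitrogen on an aromatic ring. In words, (4-methylphenyl)sulfonyl replaces (pyridin-4-yl)carbonyl on a nitrogen on an aromatic ring.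

No measured step sizes this change directly. The expectation therefore rests on compound 1, which carries the same (4-methylphenyl)sulfonyl group and gives 11000 nM. A modest move towards stronger inhibition is expected, and the estimated step is an at least 2.5-fold lower number from compound 2 to compound 3 (0.39 log units; beyond the scatter).

Compound 3 is estimated at 8000 nM, with an expected range from 2500 nM to 20000 nM.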

Compound 3, half-maximal inhibitory concentration: > 20000 nM
Compound 3: a limit, no number; the forecaster's own chance of this, stated with the estimate: 15%; middle value at least 2.5-fold (0.39 log units) away from the limit.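

In this assay compound 3 gives > 20000 nM, which is a limit and not a number. Within the data shown here, the exchange of (pyridin-4-yl)carbonyl for (4-methylphenyl)sulfonyl cannot be read as a step, and the (4-methylphenyl)sulfonyl group does not by itself bring a compound carrying 4-methylpiperazin-1-yl to a measured number: the limit of > 20000 nM in this assay, at which 2 of the 3 values shown sit. The one readable step, 4-methylpiperazin-1-yl in place of dimethylamino on an aromatic carbon, is an at least 1.8-fold higher number from compound 1 to compound 3 (0.25 log units; that floor lies within the scatter).

From the compounds shown here alone, it remains open how (pyridin-4-yl)carbonyl would read with dimethylamino on that aromatic carbon, a comparison that could give the exchange a size. Going by these compounds, it is also open whether another amine there, such as morpholin-4-yl, would give a number in this assay.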